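This account rests on a few compounds, and the source may have more. Where it says the series, first, only, none or still open, it means among the compounds named here.

Measured so far:
compound 1 `COc1ncnc2c1c(-c1ccoc1)cn2[C@@H]1O[C@H](CO)[C@@H](O)[C@H]1O`, 190 nM
compound 2 `COc1ncnc2c1c(-c1cccs1)cn2[C@@H]1O[C@H](CO)[C@@H](O)[C@H]1O`, 70 nM
compound 3 `Nc1nc2c(c(-c3cccs3)cn2[C@@H]2O[C@H](CO)[C@@H](O)[C@H]2O)c(=O)[nH]1`, > 20000 nM

In a functional assay on K562 cells (Homo sapiens), read by MTT assay, with a stated time of 72 h (on this read-out lower numbers stand for stronger inhibition and higher numbers for weaker inhibition), compound 2 gives 70 nM. Compound 1 gives 190 nM, so the change furan-3-yl in place of thiophen-2-yl on an aromatic carbon makes a step of a 2.7-fold higher number from compound 2 to compound 1 (0.43 log units; beyond the scatter). For compound 3 the value > 20000 nM is a limit of this assay and not a number; see (the limit of > 20000 nM in this assay, at which 1 of the 3 values shown sits). The difference between the core of compound 2 and the core of compound 3 is not broken down here.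

Compound 4 `Nc1nc2c(c(-c3ccoc3)cn2[C@@H]2O[C@H](CO)[C@@H](O)[C@H]2O)c(=O)[nH]1`, not yet measured, carries the same change as compound 1: furan-3-yl in place of thiophen-2-yl on an aromatic carbon. The place is the same word for word, so this is the same change. Because compound 3 already sits at a limit > 20000 nM, and because the same change gave a 2.7-fold higher number from compound 2 to compound 1 (0.43 log units; beyond the scatter), compound 4 is expected to remain at or beyond that limit, an expected step that the limit leaves unreadable from compound 3 to compound 4. The estimate for compound 4 in this assay is 50000 nM, expected range 20000 nM to 150000 nM.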

Compound 4, half-maximal inhibitory concentration: 19600 nM
For compound 4 the middle estimate is 2.6-fold (0.41 log units) above the measured one; the measured number lies below the stated range.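

In this assay, furan-3-yl in place of thiophen-2-yl on the core of the later pair gives an at least 1.0-fold lower number from compound 3 to compound 4 (0.00 log units; that floor lies within the scatter). Set beside the earlier step, the same change does not carry over unchanged from one core to the other: the same change on two cores in this assay, a 2.7-fold higher number (0.43 log units; beyond the scatter) from compound 2 to compound 1 and an at least 1.0-fold lower number (0.00 log units; that floor lies within the scatter) from compound 3 to compound 4, at least 2.7-fold (0.44 log units) apart, beyond the scatter of two such steps. The value of compound 3, > 20000 nM, is a limit of this assay and not a number, so the true size of that step stays unknown, and two cores give no rule for the series and no reason for the gap.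

Still open, on these data alone, is how each core responds at this aromatic carbon to a group other than these two rings, such as phenyl or an amine. Also open, as far as these compounds go, is which part of the difference between the core of compound 2 and the core of compound 3 matters in this read-out.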